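Cyclopropane amides on lung cancer cells: phenyl versus methylbenzyl

A few compounds are considered here, and "the series" means these few. Any claim that something is new, unique, unknown or untested is made for them only; others in the source may bear on it.

Measured compounds:
compound 1 `CCOC(=O)[C@]1(C(=O)Nc2ccccc2)C[C@H]1c1cc(OC)c(OC)c(OC)c1`: 37300 nM
compound 2 `CCOC(=O)[C@]1(C(=O)NCc2ccc(C)cc2)C[C@H]1c1cc(OC)c(OC)c(OC)c1`: 13300 nM
compound 3 `COc1cc([C@H]2C[C@]2(CO)C(=O)NCc2ccc(C)cc2)cc(OC)c1OC`: 60700 nM

These three compounds were tested in a functional assay on A549 cells (Homo sapiens) for cytotoxicity, read by MTT assay, with a stated time of 48 h; on this read-out lower numbers stand for stronger inhibition and higher numbers for weaker inhibition. In this assay compound 2 gives 13300 nM, compound 1 gives 37300 nM, and compound 3 gives 60700 nM. Compound 3 has the highest of the three numbers, but its gap to compound 1 lies within the scatter, so the two cannot be ordered; only its gap to compound 2 is beyond the scatter.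

Compound 1 and compound 2 differ in one place, where the change is phenyl in place of 4-methylbenzyl on an amide-type nitrogen. This change gave a 2.8-fold higher number from compound 2 to compound 1 (0.45 log units; beyond the scatter).

Compound 4 `COc1cc([C@H]2C[C@]2(CO)C(=O)Nc2ccccc2)cc(OC)c1OC` has not been measured. It is made from compound 3 by the same kind of change, (phenyl in place of 4-methylbenzyl on an amide-type nitrogen), and the two place lines read the same word for word. From the compounds shown here alone, the difference between the cores of compound 3 and compound 2 is not broken down here, so the effect of the core on this change is unknown.

Because the earlier step was a 2.8-fold higher number from compound 2 to compound 1 (0.45 log units; beyond the scatter), a weakening of similar size is expected here too, which is the step of a 2.3-fold higher number from compound 3 to compound 4 (0.36 log units; beyond the scatter). Compound 4 is therefore estimated at 140000 nM, with a plausible range from 50000 nM to 350000 nM; since the value of compound 3 is already high, the assay may well return only a limit.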

Compound 4, half-maximal inhibitory concentration: > 100000 nM
Compound 4 was reported as a limit; the forecaster's own chance of this, stated with the estimate: 35%; the middle value is on the limit's open side.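

In this assay compound 4 gives > 100000 nM, which is a limit of the assay and not a number. The change from 4-methylbenzyl to phenyl on the amide-type nitrogen therefore reads as an at least 1.6-fold higher number from compound 3 to compound 4 (0.21 log units; that floor lies within the scatter), so the result fits the higher number seen on the other core but does not by itself establish a rise on this one. This shows that the earlier result is not contradicted on the second core, but it does not show that the change carries over with the same size, or even that its size is similar: the same change on two cores in this assay, a 2.8-fold higher number (0.45 log units; beyond the scatter) from compound 2 to compound 1 and an at least 1.6-fold higher number (0.21 log units; that floor lies within the scatter) from compound 3 to compound 4; the limit leaves it open whether they differ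

The change replaces 4-methylbenzyl with phenyl in one go, so the compounds shown do not separate the loss of the methyl group from the loss of the carbon that links the ring to the nitrogen; a plain benzyl group or a longer phenylethyl chain on that nitrogen would bear on this. From the compounds shown here alone, it also remains open how the same change would behave on a core carrying a carboxylic acid or an amine in place of the ethyl ester or the hydroxymethyl group.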